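The compounds below may be only part of what the source reports. "The series", "measured", "known", "first", "only" and "open" are said of these compounds alone.

Measured in a functional assay on Raji cells (Homo sapiens) for cytotoxicity, with a stated time of 72 h (on this read-out lower numbers stand for an effect already at smaller amounts and higher numbers for an effect only at larger amounts of compound), each value being a limit:

Compound 1 `C=C[C@@](C)(/C=C/c1ccc(OC)cc1)CCC=C(C)C` gives > 26000 nM.
Compound 2 `C=C[C@@](C)(/C=C/c1ccc(OS(=O)(=O)C(F)(F)F)cc1)CCC=C(C)C` gives > 26000 nM.
Compound 3 `C=C[C@@](C)(/C=C/c1ccc(O)cc1)CCC(O)C(C)(C)O` gives > 26000 nM.

Compound 3 has no numerical value on this read-out, and its > 26000 nM is a limit of the assay. It stands with the other two compounds, as the limit of > 26000 nM in this assay, at which 3 of the 3 values shown sit, shows.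

Compound 4 `C=C[C@@](C)(/C=C/c1ccc(O)cc1)CC/C=C/C(=O)OCC` differs from compound 3 as follows: 2-(ethoxycarbonyl)ethenyl in place of 1,2-dihydroxy-2-methylpropyl on a saturated chain carbon, three bonds along the chain from two double-bonded chain carbons. In words, 2-(ethoxycarbonyl)ethenyl replaces 1,2-dihydroxy-2-methylpropyl on a saturated chain carbon, three bonds along the chain from two double-bonded chain carbons.

Among the measured compounds shown here, only one measured step is available, a step that the two limits leave unreadable from compound 1 to compound 2. It has no readable size, and it concerns a group on an oxygen on an aromatic ring, not this chain. For the measured compounds named here, no measured step therefore bears directly on the change. Going by the values given here, with the limit of > 26000 nM in this assay, at which 3 of the 3 values shown sit, as the only guide, no step beyond the scatter is expected in this assay, and no direction can be expected with confidence.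

The expected step is an at least 1.0-fold lower number from compound 3 to compound 4 (0.03 log units; that floor lies within the scatter).

The estimate for compound 4 is 24000 nM.

The expected range for compound 4 runs from 10000 nM to 50000 nM.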

Compound 4, half-maximal effective concentration: > 26000 nM
Compound 4 was reported as a limit; the forecaster's own chance of this, stated with the estimate: 70%; middle value at least 1.0-fold (0.03 log units) from the limit.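

In this assay compound 4 gives > 26000 nM, which is a limit of the assay. Compound 3 also carries only a limit, and the step between compound 3 and compound 4 cannot be read. The compounds shown leave open which change, if any, would give a numerical value on this read-out.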